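Amide chain length and lipophilicity in a macrolide series

A few compounds are considered here, and "the series" means these few. Any claim that something is new, unique, unknown or untested is made for them only; others in the source may bear on it.

Measured compounds:
- compound 1, `CC[C@H]1OC(=O)[C@H](C)[C@@H](O[C@H]2C[C@@](C)(OC)[C@@H](O)[C@H](C)O2)[C@H](C)[C@@H](O[C@@H]2O[C@H](C)C[C@H](N(C)CCCNC(C)=O)[C@H]2O)[C@](C)(OC)C[C@@H](C)C(=O)[C@H](C)[C@@H](O)[C@]1(C)O`: 3.08
- compound 2, `CCCCC(=O)NCCCO[C@@H]1[C@@H](C)N(C)C[C@H](C)C[C@@](C)(O)[C@H](O[C@@H]2O[C@H](C)C[C@H](N(C)C)[C@H]2O)[C@@H](C)[C@H](O[C@H]2C[C@@](C)(OC)[C@@H](O)[C@H](C)O2)[C@@H](C)C(=O)O[C@H](CC)[C@@]1(C)O`: 3.74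
- compound 3, `CCCCCCCC(=O)NCCCO[C@H]1[C@H](C)O[C@@H](O[C@H]2[C@H](C)[C@@H](O[C@@H]3O[C@H](C)C[C@H](N(C)C)[C@H]3O)[C@](C)(OC)C[C@@H](C)C(=O)[C@H](C)[C@@H](O)[C@](C)(O)[C@@H](CC)OC(=O)[C@@H]2C)C[C@@]1(C)OC`: 6.02

Three compounds have been run in a physicochemical assay for lipophilicity, read by HPLC, measured as chromatographic lipophilicity, at pH 7.4; a lower number here means a more polar compound, a higher number a more lipophilic compound. Compound 2 stands second highest of the three; its nearest neighbour is compound 1, lower by a margin beyond the scatter, and the furthest is compound 3, higher by a margin well beyond the scatter. None of the three pairs differ in one place only, so the numbers are read as they stand and not as single steps.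

Compound 4, `CC[C@H]1OC(=O)[C@H](C)[C@@H](O[C@H]2C[C@@](C)(OC)[C@@H](O)[C@H](C)O2)[C@H](C)[C@@H](O[C@@H]2O[C@H](C)C[C@H](N(C)C)[C@H]2O)[C@](C)(O)C[C@@H](C)CN(C)[C@H](C)[C@@H](OCCCNC(C)=O)[C@]1(C)O`, shares the core of compound 2 and differs from it in one place: hydrogen in place of propyl on a saturated chain carbon bound to a carbonyl carbon. Three saturated carbons leave the amide chain and nothing enters but hydrogen.

Going by the values given here, no single-change step is available to calibrate this. The shortening of the chain is expected to lower the value in this assay by a step beyond the scatter, with an estimated step of a number 0.74 log units lower from compound 2 to compound 4 (beyond the scatter). For compound 4 the estimate is 3, within a range from 2.4 to 3.6.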

Compound 4, distribution coefficient: 2.41
The estimate for compound 4 lay 0.59 log units above the measured number, and the stated range covers the measured number.
By their numbers in this assay, from the lowest: compound 4; then compound 1; then compound 2; then compound 3.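

Hydrogen in place of propyl on a saturated chain carbon bound to a carbonyl carbon gives the first single-place reading for this series in this assay, a number 1.33 log units lower from compound 2 to compound 4 (beyond the scatter), a large step. This position is therefore not silent in this read-out: butylcarbonyl to acetyl alone moves the number well past the scatter, although the leaving propyl carries no hydrogen-bond donors, no hydrogen-bond acceptors and no net charge. No measurement here bears on why the step has this size.

Going by these compounds, this is one step at one position, so whether methyl or ethyl on the same carbon would give a part of it in proportion stays unknown. On these data alone, how a carboxylic acid or an amine in that place would read on the shared core is equally open.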